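Tetrahydroisoquinoline Replaces Hydroxypiperidine on the Side Chain

The compounds below may be only part of what the source reports. "The series", "measured", "known", "first", "only" and "open" are said of these compounds alone.

Compound 1 `COc1cc2c(Nc3ccc(C#N)cc3)ncnc2cc1OCCCN(C)Cc1ccccc1`: > 100000 nM
Compound 2 `COc1cc2c(Nc3ccc(C#N)cc3)ncnc2cc1OCCCN1CCCC1`: 8080 nM
Compound 3 `COc1cc2c(Nc3ccc(C#N)cc3)ncnc2cc1OCCCN1CCC(O)CC1`: > 100000 nM

All three were tested in a functional assay on SH-SY5Y cells (Homo sapiens) for antiproliferative activity, read by MTT assay, with a stated time of 72 h; a lower number here means a stronger inhibitor, a higher number a weaker inhibitor. For compound 1 the value > 100000 nM is a limit of the assay, not a number. Compound 2 gives 8080 nM. For compound 3 the value > 100000 nM is likewise a limit. Compound 3 therefore stands at the limit of > 100000 nM in this assay, at which 2 of the 3 values shown sit. The measured steps around it are an at least 12-fold higher number from compound 2 to compound 3 (1.09 log units; beyond the scatter), an at least 12-fold lower number from compound 1 to compound 2 (1.09 log units; beyond the scatter) and a step that the two limits leave unreadable from compound 1 to compound 3. Compound 4 `COc1cc2c(Nc3ccc(C#N)cc3)ncnc2cc1OCCCN1CCc2ccccc2C1` carries the change (1,2,3,4-tetrahydroisoquinolin-2-yl in place of 4-hydroxypiperidin-1-yl on a saturated chain carbon, three bonds along the chain from an oxygen on an aromatic ring), a ring amine as in compound 2 joined to an aromatic ring as in compound 1. Since compound 3 is only a limit, the step of an at least 1.6-fold lower number from compound 3 to compound 4 (0.22 log units; that floor lies within the scatter) is expected to be unreadable or small. Compound 4 is estimated at 60000 nM.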

Compound 4, half-maximal inhibitory concentration: > 100000 nM
Compound 4 was reported as a limit (the forecaster's own chance of this, stated with the estimate: 55%); middle value at least 1.6-fold (0.22 log units) away from the limit.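

In this assay compound 4 gives > 100000 nM, which is a limit of the assay and not a number. Fusing an aromatic ring onto the ring amine at this position therefore does not recover the activity seen with pyrrolidin-1-yl, with an at least 12-fold higher number from compound 2 to compound 4 (1.09 log units; beyond the scatter), while the steps from compound 1 and from compound 3 to compound 4 cannot be read. Compound 2 alone now has a measured value, and the other compounds share one ceiling: the limit of > 100000 nM in this assay, at which 3 of the 4 values shown sit.

On these data alone, it remains open whether piperidin-1-yl, azetidin-1-yl or dimethylamino would hold a measurable value at this place. As far as these compounds go, a longer chain carrying pyrrolidin-1-yl is equally open.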